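One Ring Swapped: Estimating Removal of Compound 3

The compounds below may be only part of what the source reports. "The series", "measured", "known", "first", "only" and "open" are said of these compounds alone.

Compound 1 `NC(=O)c1sc(N2CCOCC2=O)cc1OCCc1ccccc1`: 7 mL.min-1.g-1
Compound 2 `NC(=O)c1sc(-n2nccn2)cc1OCCc1ccccc1`: 30 mL.min-1.g-1

Among the measured compounds shown here, in an ADME assay on microsomes from liver (Mus musculus, strain CD-1) for metabolic stability, read by HPLC, using NADPH, with a stated time of 30 min, in the presence of a further agent that is not named here (a lower number here means slower removal, a higher number faster removal of the compound), compound 2 gives 30 mL.min-1.g-1, the higher of the two numbers so far. The next structure, compound 3 `NC(=O)c1sc(-c2ccncc2)cc1OCCc1ccccc1`, keeps the shared core and changes one group: pyridin-4-yl in place of 2H-1,2,3-triazol-2-yl on an aromatic carbon. For the measured compounds named here, only one measured step bears on this place, where 2H-1,2,3-triazol-2-yl replaced 3-oxomorpholin-4-yl. That step, a 4.3-fold higher number from compound 1 to compound 2 (0.63 log units; beyond the scatter), is modest but beyond the usual scatter. Going by the values given here, it shows that a swap here can move the number, but it gives no direction for pyridin-4-yl, which no measured compound carries. No step beyond the scatter is therefore expected, though with real uncertainty either way. The expected step is a 1.2-fold higher number from compound 2 to compound 3 (0.07 log units; within the scatter). For compound 3 the estimated value is 35 mL.min-1.g-1, with an expected range of 12 mL.min-1.g-1 to 100 mL.min-1.g-1.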

Compound 3, intrinsic clearance in microsomes: 41 mL.min-1.g-1
The estimate for compound 3 lay 1.2-fold (0.07 log units) below the measured number; low and high end bracket the measured number.
By their numbers in this assay, from the lowest: compound 1; then compounds 2 and 3 (each within the scatter of the next).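

Replacing 2H-1,2,3-triazol-2-yl with pyridin-4-yl gives a 1.4-fold higher number from compound 2 to compound 3 (0.14 log units; within the scatter) in this assay and so shows that two quite different aromatic rings can be exchanged at this place, next to the ring sulfur, without a clear change in the number. Replacing 3-oxomorpholin-4-yl with pyridin-4-yl gives a 5.9-fold higher number from compound 1 to compound 3 (0.77 log units; beyond the scatter) and thus adds a second aromatic ring that stands clearly apart from compound 1, which keeps the lowest number of the three. Nothing available explains why these groups differ in this way.

The compounds shown leave open whether an open-chain group at this place, such as an amine or a carboxylic acid, would stay close to compound 1 or to compound 2. They also leave open whether changing the group of 9 heavy atoms elsewhere on the shared core would move the number by a similar amount.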